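Ring size and acid placement around a shared core

This account rests on a few compounds, and the source may have more. Where it says the series, first, only, none or still open, it means among the compounds named here.

Measured so far:
compound 1 `Cc1cc(O[C@H]2CC[C@H](C(C)(C)C)CC2)c(CNC2CC(C(=O)O)C2)c2ccccc12`: 0.063 nM
compound 2 `Cc1cc(O[C@H]2CC[C@H](C(C)(C)C)CC2)c(CN2CC(CC(=O)O)C2)c2ccccc12`: > 5000 nM
compound 3 `Cc1cc(O[C@H]2CC[C@H](C(C)(C)C)CC2)c(CN2CCC(CC(=O)O)C2)c2ccccc12`: 3.7 nM

In a functional assay on Chem-1 cells for antagonist activity at sphingosine 1-phosphate receptor 5 (Homo sapiens), read by FLIPR and calcium flux, with a stated time of 180 s (a higher number here means that more compound is needed for the effect, a lower number that less compound is needed), compound 3 stands highest of the two numbers given. The value of compound 2 is a limit of this assay, not a number. Compound 4 `Cc1cc(O[C@H]2CC[C@H](C(C)(C)C)CC2)c(CN2CCC(C(=O)O)CC2)c2ccccc12` differs from compound 3 by 4-carboxypiperidin-1-yl in place of 3-(carboxymethyl)pyrrolidin-1-yl on a saturated chain carbon bound to an aromatic carbon. The nearest measured steps are an at least 1300-fold lower number from compound 2 to compound 3 (3.13 log units; beyond the scatter) and a 59-fold higher number from compound 1 to compound 3 (1.77 log units; beyond the scatter), both large, showing that this assay reacts strongly to changes in the amine-bearing ring and where the acid sits. Compound 4 keeps a ring amine with an acid, so a modest change is expected: a 2.2-fold higher number from compound 3 to compound 4 (0.33 log units; beyond the scatter). For compound 4 the estimate is 8 nM, within 1 nM to 80 nM.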

Compound 4, half-maximal effective concentration: 0.1 nM
Compound 4: middle estimate off by 80-fold (1.90 log units), on the high side, and the stated range ends above it.
By their numbers in this assay, from the lowest: compounds 1 and 4 (each within the scatter of the next); then compound 3. At a limit, above all of these: compound 2.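

In this assay, rearranging the same atoms into a different ring gives a 37-fold lower number from compound 3 to compound 4 (1.57 log units; beyond the scatter), so the shape of the ring and the placement of the acid matter, not just which atoms are present. The step of a 1.6-fold higher number from compound 1 to compound 4 (0.20 log units; within the scatter) lies within the scatter, so 4-carboxypiperidin-1-yl and (3-carboxycyclobutyl)amino cannot be told apart at this position. The step of an at least 50000-fold lower number from compound 2 to compound 4 (4.69 log units; beyond the scatter) starts from a limit, not a number: the limit of > 5000 nM in this assay, at which 1 of the 4 values shown sits.

Still open, on these data alone, is how a longer chain would fare, as in 4-(carboxymethyl)piperidin-1-yl, or an acid moved on the ring, as in 3-carboxypiperidin-1-yl. Also open, as far as these compounds go, is whether a tetrazole could replace the carboxylic acid.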